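Halogen walk on the pendant phenyl ring: the bromo analogue

This account rests on a few compounds, and the source may have more. Where it says the series, first, only, none or still open, it means among the compounds named here.

Compound 1 `CCOC(=O)c1c(-c2ccccc2)[nH]c2cc(OC)ccc2c1=O` carries an unsubstituted phenyl group on the shared core. In an ADME assay on BJ cells (Homo sapiens) for cytotoxicity, read by luminescence, with a stated time of 72 h (a lower number here means that less compound is needed, a higher number that more compound is needed for the effect), compound 1 gives > 21500 nM, which is a limit of the assay rather than a number. Compound 2 `CCOC(=O)c1c(-c2cccc(F)c2)[nH]c2cc(OC)ccc2c1=O` in this assay gives > 21500 nM, again a limit. Compound 3 `CCOC(=O)c1c(-c2cccc(Cl)c2)[nH]c2cc(OC)ccc2c1=O` in this assay gives > 21500 nM, also a limit. The steps a step that the two limits leave unreadable from compound 1 to compound 2, a step that the two limits leave unreadable from compound 1 to compound 3 and a step that the two limits leave unreadable from compound 2 to compound 3 therefore cannot be sized; all that can be said is that the three halogen variants sit together at the limit of > 21500 nM in this assay, at which 3 of the 3 values shown sit.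

Compound 4 `CCOC(=O)c1c(-c2cccc(Br)c2)[nH]c2cc(OC)ccc2c1=O` differs from compound 1 by bromo in place of hydrogen on an aromatic carbon. Among the compounds with values here, the fluoro and chloro steps are the only measured changes at this carbon, and both left the cytotoxicity reading at the limit, so no direction or size can be read from them. The expectation for compound 4 is that the step that the limit leaves unreadable from compound 1 to compound 4 stays within the scatter, with a strong chance that this assay again reports only a limit. Compound 4 is estimated at 30000 nM, with a range from 12000 nM to 100000 nM.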

Compound 4, half-maximal effective concentration: > 21500 nM
Compound 4: no number, only a limit (the forecaster's own chance of this, stated with the estimate: 80%); the middle value is on the limit's open side.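

Compound 4 gives only a limit in this assay, so no step between it and compound 1, compound 2 or compound 3 can be read, and all four compounds stand together: the limit of > 21500 nM in this assay, at which 4 of the 4 values shown sit.

Left open is how compound 1, compound 2, compound 3 and compound 4 rank against one another in this assay.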